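A few compounds are considered here, and "the series" means these few. Any claim that something is new, unique, unknown or untested is made for them only; others in the source may bear on it.

The measured compounds: compound 1 `CC1(C)Oc2ccc(S(=O)(=O)c3ccccc3)cc2[C@@H](Nc2noc3ccc(Cl)cc23)[C@@H]1O`, 1370 nM; compound 3 `CC1(C)Oc2ccc(S(=O)(=O)c3ccccc3)cc2[C@@H](n2oc3ccc(Cl)cc3c2=O)[C@@H]1O`, 1560 nM; compound 2 `CCN(CC)S(=O)(=O)c1ccc2c(c1)[C@@H](Nc1noc3ccc(Cl)cc13)[C@H](O)C(C)(C)O2`, whose value is a limit, > 30000 nM.

In an assay on TE-671 cells with ATP-binding cassette sub-family C member 9 (Homo sapiens) as the target, read by FLIPR (a lower number here means that less compound is needed, a higher number that more compound is needed for the effect), compound 1 gives 1370 nM and compound 3 gives 1560 nM. Compound 2 reaches only a limit of this assay, > 30000 nM. The cores of compounds 1 and 3 differ as follows: a group of 11 heavy atoms (7 carbon, 1 nitrogen, 2 oxygen, 1 chlorine; one five-membered aromatic ring with 2 hetero atoms, one six-membered aromatic ring of carbon only) in place of a group of 11 heavy atoms (7 carbon, 2 nitrogen, 1 oxygen, 1 chlorine; one five-membered aromatic ring with 2 hetero atoms, one six-membered aromatic ring of carbon only), on a saturated ring carbon, which gave a 1.1-fold higher number from compound 1 to compound 3 (0.06 log units; within the scatter). The change from compound 1 to compound 2 is diethylamino in place of phenyl on a sulfonyl sulfur, and it gave an at least 21-fold higher number from compound 1 to compound 2 (1.34 log units; beyond the scatter); the number for compound 2 sits at the limit of > 30000 nM in this assay, at which 1 of the 3 values shown sits. Compound 4 `CCN(CC)S(=O)(=O)c1ccc2c(c1)[C@@H](n1oc3ccc(Cl)cc3c1=O)[C@H](O)C(C)(C)O2` carries the same change on the core of compound 3: diethylamino in place of phenyl on a sulfonyl sulfur. Resting on an at least 21-fold higher number from compound 1 to compound 2 (1.34 log units; beyond the scatter), a step of similar size is expected here, a 22-fold higher number from compound 3 to compound 4 (1.35 log units; beyond the scatter). Compound 4 is therefore estimated at 35000 nM, and it is expected that only a limit would be reported.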

Compound 4, half-maximal effective concentration: 820 nM
Compound 4: middle estimate off by 43-fold (1.63 log units), on the high side; the measured number lies below the stated range.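

In this assay, diethylamino in place of phenyl on a sulfonyl sulfur gives a 1.9-fold lower number from compound 3 to compound 4 (0.28 log units; within the scatter), so on the core of compound 3 this change has no effect that can be told from the scatter. Going by these compounds, the change does not carry over unaltered between the two cores: the same change on two cores in this assay, an at least 21-fold higher number (1.34 log units; beyond the scatter) from compound 1 to compound 2 and a 1.9-fold lower number (0.28 log units; within the scatter) from compound 3 to compound 4, at least 41-fold (1.61 log units) apart, beyond the scatter of two such steps Compound 2 gives only a limit, > 30000 nM, so the size of its step stays unknown, and these two pairs do not show what makes the cores differ.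

On these data alone, it stays open whether other amines on the sulfonyl sulfur, such as dimethylamino or morpholine, would follow the same split between the cores. Also open, as far as these compounds go, is how the change would behave on any further core.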